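A few compounds are considered here, and "the series" means these few. Any claim that something is new, unique, unknown or untested is made for them only; others in the source may bear on it.

Working notes on the series.

The shared core is taken as in compound 1 `C=C1C2=C(C(=O)N1OC)[C@H](OC(=O)CSc1nc3ccccc3s1)[C@@](C)(O)[C@H](CCCCC)O2`. In a functional assay on HCT-116 cells (Homo sapiens) for cytotoxicity, read by MTT assay, with a stated time of 72 h (a higher number here means a weaker inhibitor, a lower number a stronger inhibitor), compound 1 gives 4700 nM, the lowest number among the three measured. Compound 2 `C=C1C2=C(C(=O)N1OC)[C@H](O)[C@@](C)(O)[C@H](CCCCC)O2`, the free alcohol, gives 44000 nM in this assay; compound 3 `C=C1C2=C(C(=O)N1OC)[C@H](OC(=O)CCCCCl)[C@@](C)(O)[C@H](CCCCC)O2` gives 11000 nM. Two steps are known: a 2.3-fold higher number from compound 1 to compound 3 (0.37 log units; beyond the scatter), and a 4.0-fold lower number from compound 2 to compound 3 (0.60 log units; beyond the scatter). Both concern what hangs off the ester oxygen as a whole, and neither touches the aromatic ring of compound 1.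

Compound 4 `C=C1C2=C(C(=O)N1OC)[C@H](OC(=O)CSc1nc3ccccc3[nH]1)[C@@](C)(O)[C@H](CCCCC)O2` keeps the ester and the sulfur linker and changes only the ring on it: 1H-benzimidazol-2-yl in place of 1,3-benzothiazol-2-yl on a sulfur. Among the compounds with values here, no measured pair in the set isolates this ring swap, so nothing here tells its direction. Within the data shown here, the known steps show only that the ester group itself matters, with the benzothiazolyl sulfanyl ester giving the lowest number and the chlorobutyl ester a modestly higher one. With the linker and ester kept, the ring exchange is expected to shift the number little, possibly within the scatter, and for compound 4 the expected step is a 1.3-fold higher number from compound 1 to compound 4 (0.11 log units; within the scatter). Compound 4 is therefore estimated at 6000 nM in this assay, within a range of 2500 nM to 14000 nM.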

Compound 4, half-maximal inhibitory concentration: 8200 nM
Estimate against measurement, compound 4: 1.4-fold (0.14 log units) below; the measured number falls inside the stated range.
By their numbers in this assay, from the lowest: compounds 1, 4 and 3 (each within the scatter of the next, the first and the last beyond it); then compound 2.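

In this assay, the exchange of the ring itself, with the ester and the sulfur linker kept, gives a 1.7-fold higher number from compound 1 to compound 4 (0.24 log units; within the scatter), so at this place on the sulfur, 1H-benzimidazol-2-yl and 1,3-benzothiazol-2-yl are not told apart by this pair. The other new step, a 1.3-fold lower number from compound 3 to compound 4 (0.13 log units; within the scatter), also stays inside the scatter, although the two esters of compound 1 and compound 3 do separate, with a 2.3-fold higher number from compound 1 to compound 3 (0.37 log units; beyond the scatter); compound 4 therefore sits within the scatter of both and does not show whether an aromatic ring on the sulfur is needed for the number of compound 1. No supporting measurement bears on this result, so the small difference between the two rings stays without an explanation.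

Still open, from the compounds shown here alone, is whether a methyl group on the ring nitrogen that carries the hydrogen in compound 4 would leave the number in this assay unchanged. Equally open, going by these compounds, is how an amine or a carboxylic acid on the six-membered aromatic ring, or a longer chain in place of the saturated chain carbon on the sulfur, would read.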